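Working notes on cytotoxicity across compound 1 and two analogues

The compounds below may be only part of what the source reports. "The series", "measured", "known", "first", "only" and "open" are said of these compounds alone.

Measured compounds:
- compound 1, `N#Cc1ccc(CN2c3ccccc3C(=O)N(Cc3ccccc3)S2(=O)=O)cc1`: 62000 nM
- compound 2, `O=C1c2ccccc2N(Cc2ccc(-c3ccccc3)cc2)S(=O)(=O)N1Cc1ccc(-c2ccccc2)cc1`: > 47000 nM

In a functional assay on MRC5 cells (Homo sapiens) (on this read-out lower numbers stand for higher toxicity in this test and higher numbers for lower toxicity in this test), compound 1 gives 62000 nM. For compound 2 this assay gives > 47000 nM, which is a limit of the assay and not a number. Within the data shown here, compound 1 therefore holds the only number in the set; the other value sits at the limit of > 47000 nM in this assay, at which 1 of the 2 values shown sits, so no step between measured compounds can be read, and nothing can be said about how the two compare.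

Compound 3, `O=C1c2ccccc2N(Cc2cccc(Cl)c2)S(=O)(=O)N1Cc1ccccc1`, is not yet measured in this assay. It differs from compound 1 in one place: 3-chlorophenyl in place of 4-cyanophenyl on a saturated chain carbon bound to a sulfonamide nitrogen in a ring.

Among the measured compounds shown here, since no measured step exists, the size and direction of the change in this assay must be taken from the change itself. No step beyond the usual scatter is expected for compound 3 relative to compound 1. Compound 3 is estimated at 45000 nM in this assay, with a range from 20000 nM to 100000 nM. The expected step of a 1.4-fold lower number from compound 1 to compound 3 (0.14 log units; within the scatter) lies within the scatter.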

Compound 3, half-maximal cytotoxic concentration: 60000 nM
The estimate for compound 3 lay 1.3-fold (0.12 log units) below the measured number, and the stated range covers the measured number.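

In this assay, among these compounds, the change from 4-cyanobenzyl to 3-chlorobenzyl gives the first step that can be read: a 1.0-fold lower number from compound 1 to compound 3 (0.01 log units; within the scatter). At this place, on a saturated chain carbon bound to a sulfonamide nitrogen in a ring, the read-out therefore does not separate 4-cyanophenyl from 3-chlorophenyl, even though the leaving group carries a triple bond and a hydrogen-bond acceptor and the entering group carries neither. Compound 2 adds no second step, as its value is a limit of the assay and not a number: the limit of > 47000 nM in this assay, at which 1 of the 3 values shown sits.

From the compounds shown here alone, whether this insensitivity extends beyond this one pair stays open, since a single step within the scatter cannot show how far the place tolerates change, and the steps involving compound 2 cannot be read. A primary amine or a carboxylic acid on the phenyl ring, or a longer chain in place of the saturated chain carbon, could show whether any change at this place moves the number beyond the scatter, and the same question stands for the other benzyl group on the shared core.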